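Phenyl to Pyridin-2-yl: An Expected Small Step

The source may hold more compounds than are shown below. What is called first, only, known or untested is meant among the compounds shown, and "the series" means these compounds.

Compound 1 `C/C(=N\NC(=O)COc1cccc2cccnc12)c1ccccc1` was tested in an ADME assay on MCF7 cells (Homo sapiens) for cytotoxicity, read by MTT assay, with a stated time of 48 h; a higher number here means a weaker inhibitor, a lower number a stronger inhibitor. In this assay compound 1 gives > 100000 nM, which is a limit of the assay and not a number, and it sits at the limit of > 100000 nM in this assay, at which 1 of the 3 values shown sits. Two other compounds were examined alongside it. Compound 2 `Brc1ccc(-c2c[se]nn2)cc1` gives "not determined" (no result reported) in this assay. Compound 3 `c1csc(-c2csnn2)c1` gives 66900 nM in this assay. Going by the values given here, neither of these shares the core of compound 1, so no step between measured compounds is available, and the standing of compound 1 rests on its limit alone.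

Compound 4 `C/C(=N\NC(=O)COc1cccc2cccnc12)c1ccccn1` differs from compound 1 in one place: pyridin-2-yl in place of phenyl on a carbon with a double bond to nitrogen. Among the compounds with values here, with no measured step of this kind to lean on, and with compound 1 at a limit of the assay, the change is expected to be small, of a size that stays within the usual scatter in this assay, in no firm direction. Compound 4 is therefore estimated at 100000 nM, between 40000 nM and 300000 nM. The expected step is a number no higher from compound 1 to compound 4 (the limit leaves the size open).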

Compound 4, half-maximal inhibitory concentration: > 100000 nM
Compound 4: a limit, no number; the forecaster's own chance of this, stated with the estimate: 60%; the middle value lies on the limit itself.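

In this assay compound 4 gives > 100000 nM, which is a limit of the assay and not a number. Compound 1 also stands at a limit, and no step can be read between compound 1 and compound 4. Going by these compounds, whether pyridin-2-yl in place of phenyl changes the value at all remains open.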